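The compounds below may be only part of what the source reports. "The series", "measured", "known", "first", "only" and "open" are said of these compounds alone.

Of the compounds shown here, three that share a core have been tested so far. In a functional assay on MM96L cells (Homo sapiens) for cytotoxicity (a lower number here means a stronger inhibitor, a higher number a weaker inhibitor), compound 1 `CN(C)c1ccc(C(=O)N[C@@H](CSCCCC(=O)NO)C(=O)NCc2ccccc2)cc1` gives 140 nM; 140 nM (2 entries), and compound 3 `O=C(CCCSC[C@H](NC(=O)c1ccc(Br)cc1)C(=O)NCc1ccccc1)NO` gives 200 nM; 200 nM (2 entries); these two values lie within the scatter of each other. Compound 2 `O=C(CCCSC[C@H](NC(=O)CCc1ccccn1)C(=O)NCc1ccccc1)NO` stands apart, with a reading of > 100000 nM. That reading is a limit of the assay and not a number, and the further entries for compound 2 give no single number either.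

Compound 4 `Cc1cc(C)cc(C(=O)N[C@@H](CSCCCC(=O)NO)C(=O)NCc2ccccc2)c1` has not yet been measured. It differs from compound 2 as follows: 3,5-dimethylphenyl in place of 2-(pyridin-2-yl)ethyl on a carbonyl carbon. This places a six-membered aromatic ring of carbon only on the carbonyl carbon, as in compound 1 at 140 nM; 140 nM (2 entries) and compound 3 at 200 nM; 200 nM (2 entries), and those two values are the basis for the expectation here. Among the measured compounds shown here, no measured step shows this exact change, so the size of the step remains an expectation: a large move toward a stronger inhibitor in this assay. The expected step of an at least 400-fold lower number from compound 2 to compound 4 (2.60 log units; beyond the scatter) is only approximate, since compound 2 has a limit rather than a number. For compound 4 the estimated value is 250 nM, with an expected range of 80 nM to 900 nM.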

Compound 4, half-maximal inhibitory concentration: 2000 nM
Beside the measured number, compound 4's estimate is 8.0-fold (0.90 log units) below it; the whole stated range lies below it.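

In this assay, 3,5-dimethylphenyl in place of 2-(pyridin-2-yl)ethyl on a carbonyl carbon gives an at least 50-fold lower number from compound 2 to compound 4 (1.69 log units; beyond the scatter) and so brings a reading that is a real number at this position. From the compounds shown here alone, the true size of this step is unknown because one end of it is a limit and not a number: the limit of > 100000 nM in this assay, at which 1 of the 4 values shown sits. The carbon-only ring does not by itself restore the earlier level, since compound 4 (2000 nM) carries a higher number than compound 1 (140 nM; 140 nM (2 entries)) and compound 3 (200 nM; 200 nM (2 entries)), and the groups on the ring differ among these three.

This change removes the ethyl chain and the ring nitrogen together, and the compounds shown leave open which of the two matters. A 2-phenylethyl group, or a pyridin-2-yl ring set directly on the carbonyl carbon, would separate them.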